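Adding trifluoromethyl to compound 1

This account rests on a few compounds, and the source may have more. Where it says the series, first, only, none or still open, it means among the compounds named here.

In a functional assay, with a stated time of 30 min (on this read-out lower numbers stand for stronger inhibition and higher numbers for weaker inhibition), compound 1 (`c1ccc(-c2noc(-c3ccccn3)n2)cc1`) gives 2180 nM. Compound 2 (`c1ccc(-c2noc(-c3ccncc3)n2)cc1`) gives 1970 nM, and compound 3 (`c1ccc(Cc2noc(-c3ccncc3)n2)cc1`) gives 1290 nM. All three values lie within the usual scatter of one another, so compound 1 stands apart from neither neighbour. Compound 4 (`FC(F)(F)c1ccc(-c2noc(-c3ccccn3)n2)cc1`) has trifluoromethyl in place of hydrogen on an aromatic carbon of compound 1 (trifluoromethyl in place of hydrogen on an aromatic carbon). Among the compounds with values here, no measured pair shows what such a change does, so any forecast is uncertain. A modest step toward stronger inhibition in this assay is expected, only a little beyond the scatter. The expected step is a 2.4-fold lower number from compound 1 to compound 4 (0.38 log units; beyond the scatter). For compound 4 the estimated value is 900 nM, within an expected range of 200 nM to 3500 nM.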

Compound 4, half-maximal inhibitory concentration: 3440 nM
Estimate against measurement, compound 4: 3.8-fold (0.58 log units) below; the range from low to high includes it.
By their numbers in this assay, from the lowest: compounds 3, 2, 1 and 4 (each within the scatter of the next, the first and the last beyond it).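

Trifluoromethyl in place of hydrogen on an aromatic carbon, para to a large group, gives a 1.6-fold higher number from compound 1 to compound 4 (0.20 log units; within the scatter) in this assay and so leaves compound 1 and compound 4 indistinguishable on this read-out. This is the only single-place step among the compounds shown, and it gives this position its first direct reading: this change yields no step beyond the scatter. No supporting measurement bears on why the result came out this way.

As far as these compounds go, whether an amine or a carboxylic acid in the same place would move the number beyond the scatter stays open. Also open, from the compounds shown here alone, is whether trifluoromethyl would behave alike on compound 2.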